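Working notes: 2-bromophenyl to 4-methylphenyl

The source may hold more compounds than are shown below. What is called first, only, known or untested is meant among the compounds shown, and "the series" means these compounds.

In an ADME assay on Vero cells (Chlorocebus sabaeus) for cytotoxicity, read by MTT assay (a higher number here means a weaker inhibitor, a lower number a stronger inhibitor), compound 1 `C=CCOc1cc(OC)c(C(=O)/C=C/c2ccccc2)c(OCC=C)c1` gives 17100 nM and compound 2 `C=CCOc1cc(OC)c(C(=O)/C=C/c2ccccc2Br)c(OCC=C)c1` gives 13900 nM, so these two stand within the scatter of each other. Compound 3 `C=CCOc1cc(OC)c(C(=O)/C=C/c2ccc(C)cc2)c(OCC=C)c1` follows from compound 2 through (4-methylphenyl in place of 2-bromophenyl on a double-bonded chain carbon bound to a double-bonded chain carbon). Within the data shown here, one measured step bears on this change: a 1.2-fold lower number from compound 1 to compound 2 (0.09 log units; within the scatter). Among the measured compounds shown here, it covers only the bromo group, and no measured compound carries 4-methylphenyl. The step of a 1.1-fold higher number from compound 2 to compound 3 (0.03 log units; within the scatter) is therefore expected to stay within the scatter, with no direction favoured. Compound 3 is estimated at 15000 nM, with an expected range of 8000 nM to 28000 nM.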

Compound 3, half-maximal inhibitory concentration: 211000 nM
Beside the measured number, compound 3's estimate is 14-fold (1.15 log units) below it, and the stated range ends below it.
By their numbers in this assay, from the lowest: compounds 2 and 1 (each within the scatter of the next); then compound 3.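

Replacing hydrogen on the phenyl ring is not always silent in this assay: 4-methylphenyl gives a 12-fold higher number from compound 1 to compound 3 (1.09 log units; beyond the scatter), whereas the bromo step stayed within the scatter, at a 1.2-fold lower number from compound 1 to compound 2 (0.09 log units; within the scatter). Exchanging 2-bromophenyl for 4-methylphenyl likewise gives a 15-fold higher number from compound 2 to compound 3 (1.18 log units; beyond the scatter), so this position on the double-bonded chain carbon can shift the cytotoxicity number strongly. Nothing available explains this shift.

The compounds shown do not separate the identity of the methyl group from its place on the ring. A 2-methylphenyl, 4-bromophenyl or 4-methoxyphenyl group would address that question.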